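Cytotoxicity notes: aryloxy change from compound 1 to compound 4

The source may hold more compounds than are shown below. What is called first, only, known or untested is meant among the compounds shown, and "the series" means these compounds.

Compound 1 `CC(CCNC(=O)c1c(Cl)cncc1Cl)N1CCC(C(Oc2cccc(C#N)n2)c2ccc(C(F)(F)F)cc2)CC1`: 15700 nM
Compound 2 `Cc1cccc(OC(c2ccc(Br)cc2)C2CCN(C(C)CCNC(=O)c3c(Cl)cncc3Cl)CC2)n1`: 6500 nM
Compound 3 `CCO/N=C(/c1ccc(Br)cc1)C1CCN(C(C)CCNC(=O)c2c(Cl)cncc2Cl)CC1`: 33800 nM

In an ADME assay on PBMC cells (Homo sapiens) for cytotoxicity (on this read-out lower numbers stand for higher toxicity in this test and higher numbers for lower toxicity in this test), compound 1 gives 15700 nM, the second highest of the three numbers. Compound 3 gives 33800 nM, a higher number beyond the scatter, and compound 2 gives 6500 nM, a lower number beyond the scatter. Compound 4 `CC(CCNC(=O)c1c(Cl)cncc1Cl)N1CCC(C(Oc2ccc(C(F)(F)F)cc2)c2ccc(C(F)(F)F)cc2)CC1` differs from compound 1 in one place: 4-(trifluoromethyl)phenyl in place of 6-cyanopyridin-2-yl on an oxygen on a saturated carbon. Going by the values given here, no measured pair shows this change, so its effect in this assay is unknown. Given the span from compound 3 at 33800 nM to compound 2 at 6500 nM across unrelated changes, only a modest move is expected. The expected step is a 1.4-fold lower number from compound 1 to compound 4 (0.15 log units; within the scatter), close to the scatter. Compound 4 is estimated at 11000 nM, in the range 4500 nM to 28000 nM.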

Compound 4, half-maximal cytotoxic concentration: 3100 nM
The estimate for compound 4 lay 3.5-fold (0.55 log units) above the measured number; the whole stated range lies above it.
By their numbers in this assay, from the lowest: compound 4; then compound 2; then compound 1; then compound 3.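

In this assay the group on an oxygen on a saturated carbon proves able to shift the read-out on its own: 4-(trifluoromethyl)phenyl in place of 6-cyanopyridin-2-yl gives a 5.1-fold lower number from compound 1 to compound 4 (0.70 log units; beyond the scatter) and so moves toward higher toxicity in this test. The earlier compounds shown here offered no pair that isolated this position. No measurement shown here bears on the reason for this step.

As far as these compounds go, whether the step follows the loss of the ring nitrogen, the loss of the nitrile or the arrival of trifluoromethyl remains open. An unsubstituted phenyl on that oxygen would help separate these.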